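Carboxy in place of tert-butyl: working notes on the series

A few compounds are considered here, and "the series" means these few. Any claim that something is new, unique, unknown or untested is made for them only; others in the source may bear on it.

Measured in an ADME assay on MDBK cells (Bos taurus) for cytotoxicity; on this read-out higher numbers stand for lower toxicity in this test and lower numbers for higher toxicity in this test:
- compound 1 `c1ccc(Cn2ccc3nc(-c4ccccc4)nc-3c2)cc1`: > 100000 nM (a limit of the assay)
- compound 2 `COc1ccc(Cn2ccc3nc(-c4ccccc4)nc-3c2)cc1`: > 100000 nM (a limit of the assay)
- compound 3 `CC(C)(C)c1ccc(Cn2ccc3nc(-c4ccccc4)nc-3c2)cc1`: 22000 nM

Within the data shown here, compound 3 holds the only number in this set, and the other values stand at the limit of > 100000 nM in this assay, at which 2 of the 3 values shown sit. The next change leads to compound 4 `O=C(O)c1ccc(Cn2ccc3nc(-c4ccccc4)nc-3c2)cc1`, with carboxy in place of tert-butyl on an aromatic carbon. Two measured steps bring tert-butyl in, and they bear directly on this change. The first is an at least 4.5-fold lower number from compound 1 to compound 3 (0.65 log units; beyond the scatter). The second is an at least 4.5-fold lower number from compound 2 to compound 3 (0.65 log units; beyond the scatter). The remaining step, a step that the two limits leave unreadable from compound 1 to compound 2, gives no size to work with. Among the measured compounds shown here, no measured compound carries carboxy, so the expectation rests on tert-butyl leaving. In this assay the number is therefore expected to rise by a modest amount, back towards the values of the compounds without tert-butyl. The expected change is a 4.1-fold higher number from compound 3 to compound 4 (0.61 log units; beyond the scatter). A result reported only as a limit is expected to be the likelier outcome. For compound 4 the estimated value is 90000 nM. The estimated range for compound 4 runs from 40000 nM to 150000 nM.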

Compound 4, half-maximal cytotoxic concentration: > 100000 nM
Compound 4 gave a limit, no number; the forecaster's own chance of this, stated with the estimate: 70%; middle value at least 1.1-fold (0.04 log units) from the limit.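

In this assay compound 4 gives > 100000 nM, a limit of the assay and not a number. Carboxy in place of tert-butyl on this aromatic carbon gives an at least 4.5-fold higher number from compound 3 to compound 4 (0.65 log units; beyond the scatter), so the lower number seen with tert-butyl does not carry over to carboxy, a smaller group by the heavy-atom count and one that brings a hydrogen-bond donor and acceptor. The steps from compound 4 to the compounds with hydrogen and methoxy cannot be read, and these three substituents cannot be told apart at this position on this read-out: the limit of > 100000 nM in this assay, at which 3 of the 4 values shown sit.

From the compounds shown here alone, whether tert-butyl stands alone in giving a number inside the range of the assay stays open, and a longer alkyl chain, a trifluoromethyl group or an amine at the same place would test this. Going by these compounds, how far compound 1, compound 2 and compound 4 lie from one another also stays open, since a shared limit gives no order among them.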